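Swapping One Halogen for Another on the Outer Ring

The source may report more compounds than this note shows. Statements on the series, on what has been measured and on what is new or still open speak of the compounds shown alone.

Measured so far:
Compound 1, `OC(CCn1nc2c(Br)c(Br)c(Br)c(Br)c2n1)c1ccc(F)cc1`, gives 110% in a functional assay on CCRF-CEM cells (Homo sapiens) for antiproliferative activity, read by MTT assay, with a stated time of 24 h, tested at 12.5 uM; on this read-out lower numbers stand for a stronger effect and higher numbers for a weaker effect at the one concentration tested.
Compound 2, `OC(CCn1nc2c(Br)c(Br)c(Br)c(Br)c2n1)c1ccc(Br)cc1`, gives 101%.

Compound 2 and compound 1 lie within the scatter of each other on these numbers, so neither stands apart; both read as giving little effect at the concentration tested.

Compound 3, `OC(CCn1nc2c(Br)c(Br)c(Br)c(Br)c2n1)c1ccc(Cl)cc1`, is not yet measured. It differs from compound 2 by chloro in place of bromo on an aromatic carbon. For the measured compounds named here, the one measured step of the same kind, a number 9 percentage points lower from compound 1 to compound 2 (within the scatter), also exchanged one halogen for another at this spot and stayed within the scatter. With only that to go on, the change from compound 2 to compound 3 is expected to bring no step beyond the scatter in this assay, an estimated shift of a number 3 percentage points higher from compound 2 to compound 3 (within the scatter). Compound 3 is therefore expected to give about 104%, with a likely range from 90% to 118%.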

Compound 3, a percentage reported as activity, at one concentration (the size of the read-out at that concentration, not a potency): 105%
Compound 3: the middle estimate sits 1 percentage points below what was measured; the range from low to high includes it.
By their numbers in this assay, from the lowest: compounds 2, 3 and 1 (each within the scatter of the next).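

Chloro now fills the gap between fluoro and bromo on the outer ring, and in this assay the change from 4-bromophenyl to 4-chlorophenyl gives a number 4 percentage points higher from compound 2 to compound 3 (within the scatter) and the change from fluoro to chloro gives a number 5 percentage points lower from compound 1 to compound 3 (within the scatter). All three halogens at this place on the ring therefore read alike, so exchanging one for another does not separate these compounds, and none of them gains a clear effect at the one concentration tested. Nothing available explains this sameness.

From the compounds shown here alone, whether a group of another kind at this place, such as an amine or a carboxylic acid, would move the number beyond the scatter remains open. So does the effect of a longer chain between the shared core and the outer ring.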